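Adding an Amino Group to Two Nucleoside Cores

The source may hold more compounds than are shown below. What is called first, only, known or untested is meant among the compounds shown, and "the series" means these compounds.

In an ADME assay on BJ cells (Homo sapiens), read by MTT assay, with a stated time of 72 h (on this read-out lower numbers stand for stronger inhibition and higher numbers for weaker inhibition), compound 1 `COc1ncnc2c1c(-c1ccoc1)cn2[C@@H]1O[C@H](CO)[C@@H](O)[C@H]1O` gives 28800 nM. Compound 2 `COc1nc(N)nc2c1c(-c1ccoc1)cn2[C@@H]1O[C@H](CO)[C@@H](O)[C@H]1O` reaches only a limit of this assay, > 100000 nM. The change between them is amino in place of hydrogen on an aromatic carbon, and it made an at least 3.4-fold higher number from compound 1 to compound 2 (0.54 log units; beyond the scatter), ending at the limit of > 100000 nM in this assay, at which 2 of the 3 values shown sit. Compound 3 `O=c1[nH]cnc2c1c(-c1ccccc1)cn2[C@@H]1O[C@H](CO)[C@@H](O)[C@H]1O` also gives only a limit in this assay, > 100000 nM. How the core of compound 3 differs from the core of compound 1 is not broken down here. Compound 4 `Nc1nc2c(c(-c3ccccc3)cn2[C@@H]2O[C@H](CO)[C@@H](O)[C@H]2O)c(=O)[nH]1` is not yet measured in this assay; it carries the same kind of change, (amino in place of hydrogen on an aromatic carbon), with the place differing in that the amino group now sits meta to a group of 1 heavy atom rather than meta to a methoxy group. Given the earlier step of an at least 3.4-fold higher number from compound 1 to compound 2 (0.54 log units; beyond the scatter), the step from compound 3 to compound 4 is expected to be a step that the limit leaves unreadable from compound 3 to compound 4. Compound 4 is therefore estimated at 150000 nM.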

Compound 4, half-maximal inhibitory concentration: > 100000 nM
Compound 4: only a limit was reported; the forecaster's own chance of this, stated with the estimate: 85%; the middle value does not contradict the limit.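

Compound 3 and compound 4 both give only a limit, so no step between them can be read: the limit of > 100000 nM in this assay, at which 3 of the 4 values shown sit.

As far as these compounds go, whether amino in place of hydrogen shifts the number on the core of compound 3 as it did on the core of compound 1 stays open.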